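Moving One Methoxy Group on the Nitrogen-Bound Aryl

This account rests on a few compounds, and the source may have more. Where it says the series, first, only, none or still open, it means among the compounds named here.

Compound 1 `COc1cccc(OC)c1N1C(=O)CSC1c1cccc(C(=O)NCCCCc2ccccc2)c1` carries a 2,6-dimethoxyphenyl on the amide-type nitrogen of its five-membered core and is known in a functional assay on HOS-TE85 cells (Homo sapiens) for inhibition, read by CCK-8 assay, with a stated time of 72 h (a higher number here means a weaker inhibitor, a lower number a stronger inhibitor), only through a limit: compound 1 gives > 1000 nM, which is a limit of the assay rather than a number (the limit of > 1000 nM in this assay, at which 1 of the 3 values shown sits). Two related compounds with a single methoxy on that aryl and a substituent on the benzamide ring are measured: compound 2 `COc1ccccc1N1C(=O)CSC1c1cc(C(=O)NCCCCc2ccccc2)cc(C2CC2)c1` gives 23.5 nM in this assay, and compound 3 `COc1ccccc1N1C(=O)CSC1c1cc(C)cc(C(=O)NCCCCc2ccccc2)c1` gives 16.2 nM. Going by the values given here, the only one-point step among them, a 1.5-fold lower number from compound 2 to compound 3 (0.16 log units; within the scatter), concerns the benzamide ring and not the aryl on the nitrogen, so it does not bear on the change at hand.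

Compound 4 `COc1ccc(N2C(=O)CSC2c2cccc(C(=O)NCCCCc3ccccc3)c2)c(OC)c1` differs from compound 1 in a single place: 2,4-dimethoxyphenyl in place of 2,6-dimethoxyphenyl on an amide-type nitrogen in a ring. Among the compounds with values here, no measured pair in this set shares that change, so any expectation rests only on the contrast between the limit of compound 1 and the numbers of compounds 2 and 3. Compound 4 is expected to land at 300 nM, within 30 nM to 3000 nM. That estimate would mean an expected step of an at least 3.3-fold lower number from compound 1 to compound 4 (0.52 log units; beyond the scatter) toward stronger inhibition, though a result that is again only a limit remains a real possibility.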

Compound 4, half-maximal inhibitory concentration: 90.4 nM
Compound 4: the middle estimate sits 3.3-fold (0.52 log units) above what was measured; measured number inside the range.
By their numbers in this assay, from the lowest: compounds 3 and 2 (each within the scatter of the next); then compound 4. At a limit, above all of these: compound 1.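

In this assay, a change that only rearranges the same atoms, from 2,6-dimethoxyphenyl to 2,4-dimethoxyphenyl on the amide-type nitrogen, gives an at least 11-fold lower number from compound 1 to compound 4 (1.04 log units; beyond the scatter). This shows that activity at this position depends on where the methoxy groups sit on the aryl, even though the group that leaves and the group that enters have the same heavy atoms and the same count of hydrogen-bond acceptors, something compounds 2 and 3 could not show, as each differs from compound 1 in more than one place. The size of the step is only a lower bound, as compound 1 is known only through a limit of the assay: the limit of > 1000 nM in this assay, at which 1 of the 4 values shown sits.

The compounds shown leave open whether the drop in the number comes from losing the 2,6-dimethoxyphenyl pattern or from gaining the 2,4-dimethoxyphenyl one, and whether both methoxy groups of compound 4 are needed. They also do not tell how a fluorine or a hydroxyl group in place of either methoxy group would read at this position, or whether the methyl and cyclopropyl groups of compounds 3 and 2 would add to the change.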